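Methyl on a Phenol Oxygen: Expected Effect on Growth Inhibition

A few compounds are considered here, and "the series" means these few. Any claim that something is new, unique, unknown or untested is made for them only; others in the source may bear on it.

Measured compounds:
Compound 1, `Oc1ccc(-c2ccc(-c3ccc(-c4nc5ccccc5[nH]4)cc3)cc2)cc1`, gives 36000 nM in a functional assay on A2780 cells (Homo sapiens) for inhibition, read by sulforhodamine B assay; a higher number here means a weaker inhibitor of growth, a lower number a stronger inhibitor of growth.
Compound 2, `COc1ccc(-c2ccc(-c3ccc(-c4nc5ccccc5[nH]4)cc3)cc2)cc1`, gives 100000 nM in this assay.
Compound 3, `Oc1ccc(-c2ccc(-c3ccc(-c4nc5c(O)cccc5[nH]4)cc3)cc2)cc1`, gives 2920 nM in this assay.

Three compounds in this series share a common core and differ at two points. The step from compound 1 to compound 2 is the change (methyl in place of hydrogen on an oxygen on an aromatic ring), and in this assay it gave a 2.8-fold higher number from compound 1 to compound 2 (0.44 log units; beyond the scatter). The step from compound 1 to compound 3 is the change (hydroxy in place of hydrogen on an aromatic carbon), which gave a 12-fold lower number from compound 1 to compound 3 (1.09 log units; beyond the scatter); compound 3 is thus the strongest inhibitor of growth among the three measured compounds, its steps to compounds 1 and 2 both lying beyond the scatter.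

Compound 4, `COc1ccc(-c2ccc(-c3ccc(-c4nc5c(O)cccc5[nH]4)cc3)cc2)cc1`, has not yet been measured. It differs from compound 3 by the change (methyl in place of hydrogen on an oxygen on an aromatic ring), which is the same change as that from compound 1 to compound 2, made at the same place. Among the compounds with values here, the only guide to its effect is the step of a 2.8-fold higher number from compound 1 to compound 2 (0.44 log units; beyond the scatter), a modest weakening. From the compounds shown here alone, compound 4 is therefore expected to be a weaker inhibitor of growth than compound 3, with an estimated step of a 2.8-fold higher number from compound 3 to compound 4 (0.45 log units; beyond the scatter), because the earlier step of a 2.8-fold higher number from compound 1 to compound 2 (0.44 log units; beyond the scatter) was of that size; whether the second core changes this is unknown, as the change occurs only once among measured pairs. Compound 4 is estimated to give 8200 nM in this assay, most likely between 3500 nM and 25000 nM.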

Compound 4, concentration for 50% growth inhibition: 8640 nM
Compound 4: the middle estimate sits 1.1-fold (0.02 log units) below what was measured, and the stated range covers the measured number.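

In this assay, methyl in place of hydrogen on the oxygen gave a 3.0-fold higher number from compound 3 to compound 4 (0.47 log units; beyond the scatter), and this step on the hydroxy-bearing core matches the one on the core of compound 1: the same change on two cores in this assay, a 2.8-fold higher number (0.44 log units; beyond the scatter) from compound 1 to compound 2 and a 3.0-fold higher number (0.47 log units; beyond the scatter) from compound 3 to compound 4, 1.1-fold (0.03 log units) apart, within the scatter of two such steps. The added hydroxy on an aromatic carbon likewise kept its size when the oxygen carried a methyl, giving a 12-fold lower number from compound 2 to compound 4 (1.06 log units; beyond the scatter), and the two steps again agree: the same change on two cores in this assay, a 12-fold lower number (1.09 log units; beyond the scatter) from compound 1 to compound 3 and a 12-fold lower number (1.06 log units; beyond the scatter) from compound 2 to compound 4, 1.1-fold (0.03 log units) apart, within the scatter of two such steps. Within these four compounds, then, each change carried over between two cores with its size intact, but each comparison rests on a single pair of steps, so this does not show that the changes would transfer to any other core, nor does it explain why either step has the size it does.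

The compounds shown leave open whether a different group on that oxygen, such as an ethyl or a longer chain, would follow the step seen for methyl. They also leave open whether an amine or a carboxylic acid in place of the added hydroxy would bring a step like the one the hydroxy gave, on either core.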